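Working notes: hydroxyphenyl for dimethoxyphenyl on the amide series

The compounds below may be only part of what the source reports. "The series", "measured", "known", "first", "only" and "open" are said of these compounds alone.

compound 1 `O=C(OCCCc1ccccc1)c1cc(-n2cc(-c3cccc(O)c3)nn2)ccc1O`: 9%
compound 2 `COc1cc(OC)cc(-c2cn(-c3ccc(O)c(C(=O)OCCCc4ccccc4)c3)nn2)c1`: 8%
compound 3 `COc1cc(OC)cc(-c2cn(-c3ccc(O)c(C(=O)Nc4cccc(C(F)(F)F)c4)c3)nn2)c1`: 73%

All numbers come from a functional assay on CCRF-CEM cells (Homo sapiens) for inhibition, read by MTT assay, with a stated time of 2 days, tested at 10 uM; on this read-out lower numbers stand for less inhibition and higher numbers for more inhibition at the one concentration tested (going by the name of the read-out). Compound 4 `O=C(Nc1cccc(C(F)(F)F)c1)c1cc(-n2cc(-c3cccc(O)c3)nn2)ccc1O` has not yet been measured. Compound 4 differs from compound 3 by 3-hydroxyphenyl in place of 3,5-dimethoxyphenyl on an aromatic carbon. The same change, at the same place, has already been measured once in this series: a number 1 percentage points higher from compound 2 to compound 1 (within the scatter). The cores of compound 2 and compound 3 differ by (3-(trifluoromethyl)phenyl)amino in place of 3-phenylpropoxy on a carbonyl carbon, and that change gave a number 65 percentage points higher from compound 2 to compound 3 (beyond the scatter). Compound 3 therefore stands highest of the three measured numbers, beyond the scatter from compound 1 and from compound 2. Because the earlier step of a number 1 percentage points higher from compound 2 to compound 1 (within the scatter) stayed within the scatter, the step from compound 3 to compound 4 is expected to be of the same small size, a number 3 percentage points lower from compound 3 to compound 4 (within the scatter), set beside the earlier one. Compound 4 is thus estimated at 70%, between 50% and 85%.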

Compound 4, a percentage reported as inhibition, at one concentration (the size of the read-out at that concentration, not a potency): 13%
Compound 4: middle estimate off by 57 percentage points, on the high side; measured number below the stated range.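

In this assay, 3-hydroxyphenyl in place of 3,5-dimethoxyphenyl gives a number 60 percentage points lower from compound 3 to compound 4 (beyond the scatter). Among these compounds, the outcome of this change does not carry over from the core of compound 2 to the core of compound 3: the same change on two cores in this assay, a number 1 percentage points higher (within the scatter) from compound 2 to compound 1 and a number 60 percentage points lower (beyond the scatter) from compound 3 to compound 4, 61 percentage points apart, beyond the scatter of two such steps With only one pair on each core, this gives no rule for other cores, and compound 2 at 8% leaves little room on the read-out for a fall to show, so the flat earlier step does not establish that the change is harmless on that core.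

As far as these compounds go, whether the fall goes with the hydroxyl or with the loss of the methoxy groups stays open. Also open, from the compounds shown here alone, is what an amine or a carboxylic acid would give in place of that hydroxyl on either core.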